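Adding an Amino Group to an Aromatic Carbon

A few compounds are considered here, and "the series" means these few. Any claim that something is new, unique, unknown or untested is made for them only; others in the source may bear on it.

The study follows three compounds built on a shared core. Compound 1 `C[C@H]1C[C@@H](c2ccncc2NC(=O)c2nc(-c3c(F)cccc3F)ncc2N)C[C@@H](O)[C@@]1(O)CF` is the one already measured in an ADME assay on microsomes from liver (Rattus norvegicus), read by LC-MS, using NADPH, with a stated time of 30 min, tested at 1 uM; on this read-out higher numbers stand for higher hepatic extraction and lower numbers for lower hepatic extraction; in this assay compound 1 gives 0.78. Compound 2 `C[C@H]1C[C@@H](c2ccncc2NC(=O)c2ccnc(-c3c(F)cccc3F)n2)C[C@@H](O)[C@]1(C)O` was submitted to this assay, and in it compound 2 gives "not determined" (no result reported), so there is no single number on which compound 2 stands, and nothing can be said about how it compares with compound 1. Compound 3 `C[C@H]1C[C@@H](c2ccncc2NC(=O)c2nc(-c3c(F)cccc3F)ncc2N)C[C@@H](O)[C@]1(C)O` has not yet been measured. It differs from compound 2 in one place: amino in place of hydrogen on an aromatic carbon. For the measured compounds named here, no pair of measured compounds differs in one place, so the data give no step size for this change, and no direction for it can be read from compound 2, which has no number. Going by the values given here, the only anchor is compound 1, which also carries an amino group, and compound 3 is expected to sit near compound 1 because compound 1 gives 0.78 in this assay. Compound 3 is therefore estimated at 0.75 in this assay, with a range from 0.55 to 0.9.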

Compound 3, hepatic extraction ratio in the Rattus norvegicus assay: 0.85
Estimate against measurement, compound 3: 0.10 below, within the range that was stated.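

In the Rattus norvegicus assay the two amino-bearing compounds can now be set side by side, and hydrogen in place of fluoro on the saturated chain carbon gives a number 0.070 higher from compound 1 to compound 3 (within the scatter) and so leaves the hepatic extraction ratio inside the usual scatter. In a physicochemical assay for lipophilicity, at pH 7.4 (on this read-out higher numbers stand for higher lipophilicity and lower numbers for lower lipophilicity), compound 2 gives 1.3 and compound 3 gives 2.8 and this pair offers the first measured view of the amino change itself, on an aromatic carbon para to a 2,6-difluorophenyl group and two atoms from the ring nitrogen. Amino in place of hydrogen at this position goes with higher lipophilicity, something the hepatic extraction values of the earlier compounds could not show: the measured distribution coefficient of compound 2, 1.3, and of compound 3, 2.8, a number 1.50 log units higher (beyond the scatter)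

From the compounds shown here alone, the step from compound 2 to compound 3 cannot be read in the Rattus norvegicus assay, where compound 2 has no number, and what the amino group does to hepatic extraction stays open. Also open, going by these compounds, is whether a methylamino group or a methoxy group on the same aromatic carbon would move the distribution coefficient as far as the amino group does.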